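The source may report more compounds than this note shows. Statements on the series, on what has been measured and on what is new or still open speak of the compounds shown alone.

Compound 1 `C#Cc1cccc(Nc2ncnc3cc(OCCCCn4ccnc4[N+](=O)[O-])c(OC)cc23)c1` gives 2520 nM in a functional assay on HT-29 cells (Homo sapiens) for inhibition, read by sulforhodamine B assay, with a stated time of 72 h; on this read-out lower numbers stand for stronger inhibition and higher numbers for weaker inhibition. Compound 2 `C#Cc1cccc(Nc2ncnc3cc(OCCCCCn4ccnc4[N+](=O)[O-])c(OC)cc23)c1` gives 1310 nM in this assay; it differs from compound 1 by (2-nitro-1H-imidazol-1-yl)methyl in place of 2-nitro-1H-imidazol-1-yl on a saturated chain carbon, four bonds along the chain from an oxygen on an aromatic ring, and the step is a 1.9-fold lower number from compound 1 to compound 2 (0.28 log units; within the scatter). Compound 3 `COc1cc2c(Nc3ccc(OCc4cccc(F)c4)c(Cl)c3)ncnc2cc1OCCCCCn1ccnc1[N+](=O)[O-]` carries another core; the difference between the two cores is not broken down here. In this assay compound 3 gives 14100 nM, the highest number of the three. Compound 4 `COc1cc2c(Nc3ccc(OCc4cccc(F)c4)c(Cl)c3)ncnc2cc1OCCCCCCn1ccnc1[N+](=O)[O-]` is not yet measured and differs from compound 3 by (2-nitro-1H-imidazol-1-yl)methyl in place of 2-nitro-1H-imidazol-1-yl on a saturated chain carbon, five bonds along the chain from an oxygen on an aromatic ring. This is the same kind of change as that from compound 1 to compound 2, but the place differs: there the saturated chain carbon lay four bonds along the chain from an oxygen on an aromatic ring, here five bonds. Because a 1.9-fold lower number from compound 1 to compound 2 (0.28 log units; within the scatter) lay within the scatter, the expected step is a 1.6-fold lower number from compound 3 to compound 4 (0.19 log units; within the scatter), resting on that single pair. Compound 4 is estimated at 9000 nM, with an expected range from 4000 nM to 20000 nM.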

Compound 4, half-maximal inhibitory concentration: > 50000 nM
Compound 4 ended at the assay's limit (the forecaster's own chance of this, stated with the estimate: 5%); at least 5.5-fold (0.74 log units) between middle value and limit.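

On the core of compound 3, the longer chain gives an at least 3.5-fold higher number from compound 3 to compound 4 (0.54 log units; beyond the scatter). Going by these compounds, compound 4 gives > 50000 nM in this assay, which is a limit of the assay and not a number, so the full size of this step remains open. With a single pair on each core, the series shows that the change does not carry over from one core to the other in this assay, but it gives no reason for this and no general rule: the same change on two cores in this assay, a 1.9-fold lower number (0.28 log units; within the scatter) from compound 1 to compound 2 and an at least 3.5-fold higher number (0.54 log units; beyond the scatter) from compound 3 to compound 4, at least 6.8-fold (0.83 log units) apart, beyond the scatter of two such steps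

The compounds shown leave open how the chain of compound 4 behaves on the core of compound 1, and how the chain of compound 1 behaves on the core of compound 3. Also open, on these data alone, is whether an amine or a carboxylic acid in place of the 2-nitro-1H-imidazol-1-yl group at the chain end would follow either core's trend.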